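Lengthening the chain on the aromatic nitrogen

The compounds below may be only part of what the source reports. "The series", "measured", "known", "first", "only" and "open" are said of these compounds alone.

Compound 1 `CCn1c(SCc2cc([N+](=O)[O-])ccc2OC)nc2cc(NC(=O)NC(C)(C)C)ccc21` and compound 2 `CCCn1c(SCc2cc([N+](=O)[O-])ccc2OC)nc2cc(NC(=O)NC(C)(C)C)ccc21` share one core and differ only in the chain attached to an aromatic nitrogen. In an assay on isolated protein for inhibition of Gonadotropin-releasing hormone receptor (Rattus norvegicus) (on this read-out higher numbers stand for weaker inhibition and lower numbers for stronger inhibition), compound 1 gives 170 nM, and compound 2 gives 120 nM. The step between them, a 1.4-fold lower number from compound 1 to compound 2 (0.15 log units; within the scatter), is too small to count as a real change, so on these numbers compound 2 and compound 1 cannot be told apart. Compound 3 `CCCCn1c(SCc2cc([N+](=O)[O-])ccc2OC)nc2cc(NC(=O)NC(C)(C)C)ccc21` continues the same series: methyl in place of hydrogen on a saturated chain carbon, three bonds along the chain from an aromatic nitrogen, which, taken as the whole chain, reads propyl to butyl. Within the data shown here, the only measured step that bears on this is the one from compound 1 to compound 2, which stayed within the scatter; the step of a 1.2-fold lower number from compound 2 to compound 3 (0.08 log units; within the scatter) is therefore expected to be of similar size, with no clear direction beyond the scatter. Compound 3 is estimated to give 100 nM in this assay, within a range from 50 nM to 250 nM.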

Compound 3, half-maximal inhibitory concentration: 330 nM
Compound 3: the middle estimate sits 3.3-fold (0.52 log units) below what was measured; measured number above the stated range.
By their numbers in this assay, from the lowest: compounds 2, 1 and 3 (each within the scatter of the next, the first and the last beyond it).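

Among these compounds, the move from propyl to butyl gives the first step at this position that lies beyond the scatter: in this assay it is a 2.8-fold higher number from compound 2 to compound 3 (0.44 log units; beyond the scatter), a modest weakening of inhibition. A methyl added three bonds along the chain from the aromatic nitrogen therefore has a measurable effect on the number, which the methyl added two bonds along did not show. Butyl still cannot be told apart from ethyl, as a 1.9-fold higher number from compound 1 to compound 3 (0.29 log units; within the scatter) stays within the scatter, so the loss is clear only against propyl.

From the compounds shown here alone, how a pentyl chain, a branched isopropyl group or a chain ending in an amine would fare at this nitrogen remains open. No measurement offered here explains why the butyl chain behaves this way.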